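Naphthalen-1-yl in place of 4-chlorophenyl on a sulfur

This account rests on a few compounds, and the source may have more. Where it says the series, first, only, none or still open, it means among the compounds named here.

Compound 1 `Nc1ccccc1NC(=O)/C=C/c1ccc(CSc2ccc(Cl)cc2)cc1`: 15.2%
Compound 2 `Nc1ccccc1NC(=O)c1ccc(CSc2ccc(Br)cc2)cc1`: 10%

In a functional assay on SMMC-7721 cells (Homo sapiens) for inhibition, read by CCK-8 assay, with a stated time of 72 h, tested at 2 uM (on this read-out lower numbers stand for less inhibition of growth and higher numbers for more inhibition of growth at the one concentration tested), compound 1 gives 15.2% and compound 2 gives 10%. For the measured compounds named here, these two values lie within the usual scatter of each other, so compound 1 stands level with the only other compound measured. The next compound to be tested is compound 3 `Nc1ccccc1NC(=O)/C=C/c1ccc(CSc2cccc3ccccc23)cc1`, which carries naphthalen-1-yl in place of 4-chlorophenyl on a sulfur. Going by the values given here, no measured pair differs in one place only, so the data give no size for such a change. In this assay no step beyond the scatter is expected, and the data favour no direction. The estimate amounts to an expected step of a number 2.8 percentage points higher from compound 1 to compound 3 (within the scatter). For compound 3 the estimated value is 18%, with an expected range from 6% to 38%.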

Compound 3, percent growth inhibition at one concentration: 3.7%
Beside the measured number, compound 3's estimate is 14.3 percentage points above it; measured number below the stated range.
By their numbers in this assay, from the lowest: compounds 3, 2 and 1 (each within the scatter of the next, the first and the last beyond it).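

In this assay, for the compounds shown here, the group on a sulfur now has a measured effect: with naphthalen-1-yl in place of 4-chlorophenyl, the value is a number 11.5 percentage points lower from compound 1 to compound 3 (beyond the scatter), the first change in a single place in this set. The exchange replaces one six-membered aromatic ring of carbon only, bearing chlorine, with two such rings, so the loss of chlorine and the gain in rings arrive together and this one pair cannot separate them. Nothing measured here accounts for the step.

From the compounds shown here alone, it remains open how an unsubstituted phenyl or a benzyl group on the sulfur would read, either of which could help separate the loss of chlorine from the added ring. Also open, going by these compounds, is whether the same exchange would give a similar step on the core of compound 2.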